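Amino-to-methyl on the thiadiazole across two chromone cores

This account rests on a few compounds, and the source may have more. Where it says the series, first, only, none or still open, it means among the compounds named here.

Compound 1 `Cc1nnc(SCc2cc(=O)c3ccccc3o2)s1` and compound 2 `Nc1nnc(SCc2cc(=O)c3ccccc3o2)s1` share one core. In a functional assay on HEp-2 cells (Homo sapiens) for cytotoxicity, read by MTT assay, with a stated time of 72 h (a higher number here means a weaker inhibitor, a lower number a stronger inhibitor), compound 1 gives > 25000 nM, a limit of the assay. In this assay compound 2 gives > 25000 nM, also a limit. Their change, (methyl in place of amino on an aromatic carbon), yields a step that the two limits leave unreadable from compound 2 to compound 1, because of the limit of > 25000 nM in this assay, at which 2 of the 3 values shown sit. Compound 3 `Nc1nnc(SCc2coc3ccccc3c2=O)s1` has the atoms of compound 2 joined differently; the difference between the two cores is not broken down here. In this assay compound 3 gives 1500 nM. Compound 4 `Cc1nnc(SCc2coc3ccccc3c2=O)s1` is not yet measured; it differs from compound 3 by methyl in place of amino on an aromatic carbon, the same change as that from compound 2 to compound 1, which was unreadable. Since that earlier step gives no size, the step from compound 3 to compound 4 is estimated near neutral at a 1.7-fold higher number from compound 3 to compound 4 (0.22 log units; within the scatter), with wide uncertainty. Compound 4 is therefore expected at 2500 nM, between 800 nM and 12000 nM.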

Compound 4, half-maximal inhibitory concentration: 2900 nM
Compound 4: the middle estimate sits 1.2-fold (0.06 log units) below what was measured; measured number inside the range.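

In this assay, methyl in place of amino gives a 1.9-fold higher number from compound 3 to compound 4 (0.29 log units; within the scatter), so on the core of compound 3 the change from 5-amino-1,3,4-thiadiazol-2-yl to 5-methyl-1,3,4-thiadiazol-2-yl has no size that stands clear of the scatter. The same change on the core of compound 1 cannot be read, because compound 1 and compound 2 both sit at a limit of the assay: the limit of > 25000 nM in this assay, at which 2 of the 4 values shown sit. The readable pair therefore speaks for one core only, and it neither confirms nor rules out that the change carries from one core to the other.

From the compounds shown here alone, what a carboxylic acid or a longer chain such as propyl would do in place of the amino group remains open. Also open, going by these compounds, is whether any group on the core of compound 1 gives a value off that limit.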